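The compounds below may be only part of what the source reports. "The series", "measured", "known", "first", "only" and "open" are said of these compounds alone.

Compound 1: `CN(c1cccc2c1CCCC2c1c[nH]cn1)S(C)(=O)=O`
Compound 2: `CCCS(=O)(=O)Nc1cccc2c1CCCC2c1c[nH]cn1`
Compound 3: `CC(=O)Nc1cccc2c1CCCC2c1c[nH]cn1`

In an assay on isolated protein (Cricetulus griseus) for binding affinity to Alpha-1B adrenergic receptor (Mesocricetus auratus), read by radioligand binding (a lower number here means a stronger inhibitor, a higher number a weaker inhibitor), compound 1 gives < 10000 nM, which is a limit of the assay and not a number. Compound 2 gives < 10000 nM, again only a limit. Compound 3 gives < 10000 nM, likewise a limit. All three values sit at the limit of < 10000 nM in this assay, at which 3 of the 3 values shown sit, so compound 3 cannot be placed relative to the other two. Compound 4 `O=C(Nc1cccc2c1CCCC2c1c[nH]cn1)C(F)(F)F` differs from compound 3 by trifluoromethyl in place of methyl on a carbonyl carbon. The measured steps a step that the two limits leave unreadable from compound 1 to compound 2, a step that the two limits leave unreadable from compound 1 to compound 3 and a step that the two limits leave unreadable from compound 2 to compound 3 give no readable size, and none of them touches the carbonyl carbon, so no direction beyond the scatter can be drawn from them. Compound 4 is therefore estimated at 3000 nM, within 300 nM to 10000 nM. The step expected is a step that the limit leaves unreadable from compound 3 to compound 4.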

Compound 4, inhibition constant: < 10000 nM
Compound 4 ended at the assay's limit; the forecaster's own chance of this, stated with the estimate: 70%; the middle value is on the limit's open side.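

Compound 4, like compound 1, compound 2 and compound 3, gives only a limit, so no step among them can be read: the limit of < 10000 nM in this assay, at which 4 of the 4 values shown sit.

The compounds shown leave open where each truly stands, and what trifluoromethyl in place of methyl on a carbonyl carbon does to the value.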